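The compounds below may be only part of what the source reports. "The series", "measured", "known", "first", "only" and "open" are said of these compounds alone.

In a functional assay on WRL68 cells (Homo sapiens) for cytotoxicity, read by MTT assay, with stated times of 6 h and 48 h (on this read-out lower numbers stand for stronger inhibition and higher numbers for weaker inhibition), compound 1 `Cn1c(/C=C/C(=O)c2ccccc2O)cc(Br)c1Br` gives 330 nM. For compound 2 `Cn1c(/C=C/C(=O)c2cccc(O)c2)cc(Br)c1Br`, which shares the same core, the assay reports only a limit, >= 100000 nM, and no number. Compound 3 `Cn1c(/C=C/C(=O)c2cc(O)ccc2O)cc(Br)c1Br` differs from compound 2 in one place: hydroxy in place of hydrogen on an aromatic carbon. This is hydroxy in place of hydrogen on an aromatic carbon, ortho to a large group and para to a hydroxy group. Compound 3 therefore carries the hydroxy of compound 1 as well as that of compound 2. A large step towards stronger inhibition is expected in this assay. That expectation rests on compound 1, with its 330 nM, although the retained hydroxy of compound 2 leaves the size of the step uncertain. The expected step is an at least 66-fold lower number from compound 2 to compound 3 (1.82 log units; beyond the scatter). For compound 3 the estimated half-maximal inhibitory concentration is 1500 nM, with an expected range of 150 nM to 20000 nM.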

Compound 3, half-maximal inhibitory concentration: 880 nM
Compound 3: middle estimate off by 1.7-fold (0.23 log units), on the high side; the measured number falls inside the stated range.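

In this assay, the hydroxy that enters ortho to a large group gives an at least 110-fold lower number from compound 2 to compound 3 (2.05 log units; beyond the scatter), so this position separates compound 3 from compound 2 by a wide margin. Compound 2 has a limit of the assay and not a number, so the true size of the step cannot be read: the limit of >= 100000 nM in this assay, at which 1 of the 3 values shown sits. The comparison with compound 1 adds that the hydroxy shared by compound 2 and compound 3 brings only a 2.7-fold higher number from compound 1 to compound 3 (0.43 log units; beyond the scatter), so the low number survives with this second hydroxy present.

The compounds shown leave open whether a hydroxy is specifically required at this position, or whether a methoxy group or an amine there would give a similar number. They also leave open whether the same step would appear on a different core.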